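Trifluoromethyl for methoxy on the cytotoxic bis-benzylidene series

The source may hold more compounds than are shown below. What is called first, only, known or untested is meant among the compounds shown, and "the series" means these compounds.

Two compounds of the shared core carry numbers in a functional assay on BGC-823 cells (Homo sapiens) for cytotoxicity, read by CCK-8 assay, with a stated time of 72 h; on this read-out higher numbers stand for weaker inhibition and lower numbers for stronger inhibition. Compound 1 `C=CCn1c(=O)/c(=C\c2ccccc2Cl)[nH]c(=O)/c1=C\c1ccccc1OC` gives 4600 nM. Going by the values given here, compound 2 `C=CCn1c(=O)/c(=C\c2ccccc2OC)[nH]c(=O)/c1=C\c1ccccc1OC` gives 13400 nM, the highest of the two numbers; the step of a 2.9-fold higher number from compound 1 to compound 2 (0.46 log units; beyond the scatter) is the only measured step and it separates the two compounds beyond the scatter.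

Compound 3 `C=CCn1c(=O)/c(=C\c2ccccc2C(F)(F)F)[nH]c(=O)/c1=C\c1ccccc1OC` is not yet measured. It differs from compound 2 by trifluoromethyl in place of methoxy on an aromatic carbon, on an aromatic carbon of a six-membered aromatic ring of carbon only, ortho to a large group.

The step from compound 1 to compound 2 bears on this change only in part: it exchanged chloro for methoxy at the same place and raised the number by a modest amount. Among the compounds with values here, no measured step shows trifluoromethyl at that place. Taking methoxy away is expected to move the number back toward that of compound 1, so a modest decrease a 2.1-fold lower number from compound 2 to compound 3 (0.31 log units; beyond the scatter) in this assay is expected for compound 3. Compound 3 is therefore estimated at 6500 nM, with a range from 2500 nM to 17000 nM.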

Compound 3, half-maximal inhibitory concentration: 5100 nM
Beside the measured number, compound 3's estimate is 1.3-fold (0.11 log units) above it; low and high end bracket the measured number.
By their numbers in this assay, from the lowest: compounds 1 and 3 (each within the scatter of the next); then compound 2.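

In this assay the exchange of 2-methoxyphenyl for 2-(trifluoromethyl)phenyl gives a 2.6-fold lower number from compound 2 to compound 3 (0.42 log units; beyond the scatter) and so shows a second group, after chloro, that differs from methoxy on this aromatic carbon beyond the scatter. Trifluoromethyl and chloro cannot be told apart at this place, with a 1.1-fold higher number from compound 1 to compound 3 (0.04 log units; within the scatter) as the step between them in this assay and the two compounds forming one level. Among these three compounds methoxy alone stands apart, a pattern that reaches no further than the three groups shown, and nothing at hand accounts for it.

An amine, a carboxylic acid or a longer chain on this aromatic carbon remains open, so the compounds shown cannot tell whether the level held by chloro and trifluoromethyl is a floor for this place or only one step on a wider range. Also open, going by these compounds, is whether the same exchange would read the same way on the 2-methoxyphenyl group that all three compounds share, or with a group other than the allyl chain on the core.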